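Swapping Methyl for Phenyl on the Ether Oxygen

The compounds below may be only part of what the source reports. "The series", "measured", "known", "first", "only" and "open" are said of these compounds alone.

Measured so far:
Compound 1 `Cc1cc(Sc2ccccc2Cl)c(S(C)(=O)=O)cc1C(=O)N=C(N)N` — in a functional assay for inhibition of sodium/hydrogen exchanger (Oryctolagus cuniculus) (a higher number here means a weaker inhibitor, a lower number a stronger inhibitor), compound 1 gives 14 nM
Compound 2 `COc1cc(C)c(C(=O)N=C(N)N)cc1S(C)(=O)=O` — in this assay compound 2 gives 16 nM

Of the two measured compounds, compound 2 stands within the scatter of compound 1: the step of a 1.1-fold higher number from compound 1 to compound 2 (0.06 log units; within the scatter) does not separate them. Compound 3 `Cc1cc(Oc2ccccc2)c(S(C)(=O)=O)cc1C(=O)N=C(N)N` differs from compound 2 by phenyl in place of methyl on an oxygen on an aromatic ring. Among the measured compounds shown here, only one measured step bears on this, and only indirectly: a 1.1-fold higher number from compound 1 to compound 2 (0.06 log units; within the scatter) shows that replacing (2-chlorophenyl)sulfanyl, which itself carries an aromatic ring, with methoxy changed nothing beyond the scatter. Putting a phenyl ring back onto the oxygen is therefore expected to leave this assay about where compound 2 sits, and the expected step of a 1.1-fold lower number from compound 2 to compound 3 (0.03 log units; within the scatter) is none beyond the scatter. For compound 3 the estimate is 15 nM, with a range from 5 nM to 45 nM.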

Compound 3, half-maximal inhibitory concentration: 10 nM
Compound 3: the middle estimate sits 1.5-fold (0.18 log units) above what was measured; low and high end bracket the measured number.
By their numbers in this assay, from the lowest: compounds 3, 1 and 2 (each within the scatter of the next).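

In this assay, among the compounds shown here, the step of a 1.6-fold lower number from compound 2 to compound 3 (0.20 log units; within the scatter) is the first direct reading of this swap, and it shows that six heavy atoms of phenyl can stand on this oxygen in place of the single carbon of methyl without a shift beyond the scatter. The step of a 1.4-fold lower number from compound 1 to compound 3 (0.15 log units; within the scatter) adds that phenoxy and (2-chlorophenyl)sulfanyl on this aromatic carbon cannot be told apart either, so methoxy, phenoxy and (2-chlorophenyl)sulfanyl all read alike here. No supporting measurement is available to explain this result.

The compounds shown leave open whether this tolerance extends to a quite different kind of group on the same aromatic carbon, such as an amine or a carboxylic acid. They also leave open how a longer chain on the oxygen, such as butyl, would read.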